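A few compounds are considered here, and "the series" means these few. Any claim that something is new, unique, unknown or untested is made for them only; others in the source may bear on it.

Within the data shown here, in an assay on cells for positive allosteric modulation of Cystic fibrosis transmembrane conductance regulator variant F508del (Homo sapiens), with stated times of 10 min and 7 s, in the presence of a further agent that is not named here (a higher number here means that more compound is needed for the effect, a lower number that less compound is needed), compound 2 `CC1(C)Cc2c(sc(NC(=O)C(C)(C)O)c2C(N)=O)C(C)(C)O1` gives 16 nM, the highest of the two numbers measured so far. Among the measured compounds shown here, its nearest neighbour is compound 1 `CC1(C)Cc2c(sc(NC(=O)c3ccn[nH]3)c2C(N)=O)C(C)(C)O1`, which in this assay gives 3 nM; the step of a 5.3-fold higher number from compound 1 to compound 2 (0.73 log units; beyond the scatter) is the only measured step, and it lies beyond the scatter. Compound 3 `CC1(C)Cc2c(sc(NC(=O)C(C)(C)CO)c2C(N)=O)C(C)(C)O1` has not yet been measured. It differs from compound 2 by hydroxymethyl in place of hydroxy on a saturated chain carbon bound to a carbonyl carbon and two saturated chain carbons. For the measured compounds named here, no measured step covers this kind of change: the step from compound 1 to compound 2 exchanges the whole group on the carbonyl carbon, whereas compound 3 keeps that group and alters only its hydroxy end. The measured data therefore give no direction for this change, and the expected step of a 1.1-fold higher number from compound 2 to compound 3 (0.05 log units; within the scatter) is one that stays within the scatter. Compound 3 is therefore estimated to give 18 nM in this assay, with a range from 6 nM to 60 nM.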

Compound 3, half-maximal effective concentration: 75 nM
Compound 3: middle estimate off by 4.2-fold (0.62 log units), on the low side, outside the stated range (above it).
By their numbers in this assay, from the lowest: compound 1; then compound 2; then compound 3.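

In this assay the saturated chain carbon bound to a carbonyl carbon and two saturated chain carbons proves sensitive to a small change: hydroxymethyl in place of hydroxy gives a 4.7-fold higher number from compound 2 to compound 3 (0.67 log units; beyond the scatter) even though the counts of hydrogen-bond donors and acceptors stay the same. Measured against the 1H-pyrazol-5-yl group, the 1-(hydroxymethyl)-1-methylethyl group gives a 25-fold higher number from compound 1 to compound 3 (1.40 log units; beyond the scatter) and is thus further from compound 1 than the 1-hydroxy-1-methylethyl group is. Nothing available accounts for either step.

As far as these compounds go, whether a longer chain ending in hydroxy would raise the number further, and whether an amine or a carboxylic acid could take the place of the hydroxy, remains open. Also open, from the compounds shown here alone, is what a plain methyl at that place would give, and with it how much the hydroxy itself contributes.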